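The source may report more compounds than this note shows. Statements on the series, on what has been measured and on what is new or still open speak of the compounds shown alone.

Working notes on the series. The first compound, compound 1 `Cc1nc2c(OCc3ccccc3)cccn2c1N`, was tested in a functional assay on the whole organism with Canis familiaris (Canis lupus familiaris) as the target, at a dose of 8 mg/kg by the oral route (a higher number here means a stronger effect of the compound at the dose given, a lower number a weaker effect), where compound 1 gives 96%. Compound 2 `Cc1nc2c(OCc3ccc(F)cc3)cccn2c1N` carries a fluoro in place of hydrogen on an aromatic carbon; in this assay compound 2 gives 93%. For the measured compounds named here, the step of a number 3 percentage points lower from compound 1 to compound 2 (within the scatter) is within the scatter, so compound 2 stands alongside compound 1, the only other number so far, with no separation between them that the measurement can resolve.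

Compound 3 `Cc1nc2c(OCc3ccc(Cl)cc3)cccn2c1N` is the next member. The change from compound 2 is chloro in place of fluoro on an aromatic carbon. Going by the values given here, only one measured step exists, a number 3 percentage points lower from compound 1 to compound 2 (within the scatter), and it concerns a different exchange, hydrogen for fluoro, at the same kind of aromatic carbon; it showed nothing beyond the scatter. Among the compounds with values here, no measured step covers fluoro against chloro. With both numbers close to the ceiling of what this read-out can report, the step of a number 2 percentage points lower from compound 2 to compound 3 (within the scatter) is expected to stay within the scatter, in no clear direction. Compound 3 is therefore estimated at 91%, with a range from 76% to 99%.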

Compound 3, a percentage reported as inhibition, in the whole organism at one dose (the size of the read-out at that dose, not a potency): 92%
The estimate for compound 3 lay 1 percentage points below the measured number; the range from low to high includes it.
By their numbers in this assay, from the lowest: compounds 3, 2 and 1 (each within the scatter of the next).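

Chloro at this place extends what the fluoro analogue alone could show: in this assay, the exchange of fluoro for chloro gives a number 1 percentage points lower from compound 2 to compound 3 (within the scatter), and the exchange of hydrogen for chloro gives a number 4 percentage points lower from compound 1 to compound 3 (within the scatter). Across these three compounds, hydrogen, fluoro and chloro on this aromatic carbon, para to a large group, cannot be told apart by a read-out that gives the size of the effect at one dose and not a potency, so this place accepts either halogen without a step that the measurement can resolve. No measured data on hand offer an explanation for this result.

The compounds shown leave open whether a group other than a halogen at this carbon, such as a methoxy, an amine or a carboxylic acid, would give a step beyond the scatter. They also leave open whether chloro or fluoro on another carbon of the same ring would behave in the same way, and whether the three compounds would separate in the size of their effect at other doses.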